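This account rests on a few compounds, and the source may have more. Where it says the series, first, only, none or still open, it means among the compounds named here.

Two compounds measured in an assay for inhibition of Tryptophan 2,3-dioxygenase (Homo sapiens), with stated times of 10 min and 60 min, tested at 10 uM (on this read-out lower numbers stand for a weaker effect and higher numbers for a stronger effect at the one concentration tested), frame the series. Compound 1 `O=[N+]([O-])c1cc(OCc2ccccc2)ccc1CNc1cc(C(F)(F)F)cc2[nH]ncc12` gives 49% in this assay, and compound 2 `FC(F)(F)c1cccc(CNc2cc(C(F)(F)F)cc3[nH]ncc23)c1` gives 40%. Compound 2 thus holds the lower of the two numbers, yet the gap to compound 1 lies within the scatter, so no order between them can be claimed. Compound 3 `Nc1cccc(CNc2cc(C(F)(F)F)cc3[nH]ncc23)c1` follows from compound 2 by amino in place of trifluoromethyl on an aromatic carbon. Going by the values given here, no measured pair shows such a change, so the direction is open. The step is estimated as a number 10 percentage points lower from compound 2 to compound 3 (within the scatter), a small decrease not clearly beyond the scatter. For compound 3 the expected inhibition is 30%, in a range from 10% to 55%.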

Compound 3, a percentage reported as inhibition, at one concentration (the size of the read-out at that concentration, not a potency): 68%
Compound 3: middle estimate off by 38 percentage points, on the low side; the measured number lies above the stated range.
By their numbers in this assay, from the lowest: compounds 2 and 1 (each within the scatter of the next); then compound 3.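

On an aromatic carbon, meta to a large group, amino in place of trifluoromethyl gives a number 28 percentage points higher from compound 2 to compound 3 (beyond the scatter) in this assay and marks this position as sensitive to the group it carries. Compound 1 and compound 2 differ in more than one place and could not show this.

From the compounds shown here alone, whether the gain comes from adding amino or from losing trifluoromethyl remains open, and a bare hydrogen, a hydroxyl or a methylamine at this position would help separate the two. Nothing available accounts for the size of this step.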